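The source may report more compounds than this note shows. Statements on the series, on what has been measured and on what is new or still open speak of the compounds shown alone.

Series so far, in a functional assay on A549 cells (Homo sapiens) for inhibition, read by CCK-8 assay, with a stated time of 72 h, tested at 2 uM; a higher number here means more inhibition of growth at the concentration tested, a lower number less inhibition of growth:
- compound 1 `Nc1ccccc1NC(=O)/C=C/c1ccc(CSc2cccc(F)c2)cc1`: 50.7%
- compound 2 `COc1ccc(SCc2ccc(C(=O)Nc3ccccc3N)cc2)cc1`: 45.7%
- compound 3 `COC(=O)c1ccccc1SCc1ccc(C(=O)Nc2ccccc2N)cc1`: 44.7%

Compound 1 stands level with compound 2 and compound 3, as all three values lie within the scatter. Compound 4 `CC(C)(C)c1ccc(SCc2ccc(/C=C/C(=O)Nc3ccccc3N)cc2)cc1` keeps the core of compound 1 and changes one group: 4-(tert-butyl)phenyl in place of 3-fluorophenyl on a sulfur. The 4-(tert-butyl)phenyl replaces the 3-fluorophenyl on a sulfur. Among the measured compounds shown here, no measured step isolates this change. For the measured compounds named here, the only guide is the narrow spread of values, with compound 2 at 45.7% and compound 3 at 44.7%. No shift beyond the scatter is expected in this assay, though a slight downward drift is estimated, a number 4.7 percentage points lower from compound 1 to compound 4 (within the scatter). For compound 4 the estimated value is 46%, with an expected range of 33% to 58%.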

Compound 4, percent growth inhibition at one concentration: 71.5%
Compound 4: middle estimate off by 25.5 percentage points, on the low side, and the stated range ends below it.
By their numbers in this assay, from the lowest: compounds 3, 2 and 1 (each within the scatter of the next); then compound 4.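

Among the compounds shown here, compound 4 gives the first step beyond the scatter: 4-(tert-butyl)phenyl in place of 3-fluorophenyl on a sulfur gives a number 20.8 percentage points higher from compound 1 to compound 4 (beyond the scatter) in this assay. The group on this sulfur is therefore not a silent position in the core of compound 1, and the larger, fluorine-free aryl group is accepted there. Nothing at hand explains the step.

Open, on these data alone, is whether a phenyl, 4-isopropylphenyl or cyclohexyl group on the same sulfur gives a similar value. Also open, as far as these compounds go, is whether the 4-(tert-butyl)phenyl group has the same effect on the core of compound 2.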